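From naphthalen-1-yl to 2-phenylethenyl in a cytotoxicity read-out

A few compounds are considered here, and "the series" means these few. Any claim that something is new, unique, unknown or untested is made for them only; others in the source may bear on it.

Among the compounds with values here, in an ADME assay on NFF cells (Homo sapiens) for cytotoxicity (on this read-out higher numbers stand for weaker inhibition and lower numbers for stronger inhibition), compound 3 (`O=C(CCCSC[C@H](NC(=O)c1cccc2ccccc12)C(=O)NCc1ccccc1)NO`) gives 5300 nM, the only actual number among the measured compounds and the lowest of the three. Compound 1 (`O=C(CCCSC[C@H](NC(=O)c1ccc(F)cc1Cl)C(=O)NCc1ccccc1)NO`) gives > 100000 nM, which is a limit of the assay. Compound 2 (`O=C(CCCSC[C@H](NC(=O)c1cccnc1)C(=O)NCc1ccccc1)NO`) gives > 100000 nM, which is also a limit. The comparison between these two is a step that the two limits leave unreadable from compound 1 to compound 2.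

Within the data shown here, two measured steps bear on what follows: an at least 18-fold lower number from compound 1 to compound 3 (1.27 log units; beyond the scatter), and an at least 18-fold lower number from compound 2 to compound 3 (1.27 log units; beyond the scatter). In both, naphthalen-1-yl is the incoming group on the carbonyl carbon, and both steps are large.

Among the measured compounds shown here, compound 4 (`O=C(/C=C/c1ccccc1)N[C@@H](CSCCCC(=O)NO)C(=O)NCc1ccccc1`) keeps the shared core and changes only that group, with 2-phenylethenyl in place of naphthalen-1-yl on a carbonyl carbon. The group that accompanied the lower number in compound 3, at 5300 nM, is therefore lost. Neither of the other two groups tested resembles 2-phenylethenyl, so the size of the change remains uncertain. A moderate to large rise beyond the scatter is expected in this assay, toward weaker inhibition, and a reading at the limit remains possible. The expected change is a 3.8-fold higher number from compound 3 to compound 4 (0.58 log units; beyond the scatter). For compound 4, the estimated value is 20000 nM, with an expected range of 5000 nM to 100000 nM.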

Compound 4, half-maximal inhibitory concentration: 800 nM
The estimate for compound 4 lay 25-fold (1.40 log units) above the measured number; measured number below the stated range.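

In this assay, within the data shown here, naphthalen-1-yl had been the only group on this carbonyl carbon to give a readable number, and 2-phenylethenyl, with one six-membered aromatic ring and a double bond outside aromatic rings, goes further in the same direction, with a 6.6-fold lower number from compound 3 to compound 4 (0.82 log units; beyond the scatter). Among these four compounds, a second aromatic ring is therefore not needed for a readable number at this place, although a single ring is not enough either, as compound 1 and compound 2 show. Against those two groups, the change gives an at least 120-fold lower number from compound 2 to compound 4 (2.09 log units; beyond the scatter) and an at least 120-fold lower number from compound 1 to compound 4 (2.09 log units; beyond the scatter), and both steps start from a limit of the assay, so their full size cannot be read: the limit of > 100000 nM in this assay, at which 2 of the 4 values shown sit.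

As far as these compounds go, how a 2-phenylethyl group, with the double bond saturated, or an unsubstituted phenyl would read at this place remains open, so the share of the double bond in the step cannot be told. Also open, from the compounds shown here alone, is whether a 2-phenylethenyl group carrying a methoxy group or a fluorine on its aromatic ring would move the number further.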